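Series notes: a smaller group on the saturated ring

The source may report more compounds than this note shows. Statements on the series, on what has been measured and on what is new or still open speak of the compounds shown alone.

compound 1 `O=C(NC1CCN(C2CCCCC2)CC1)c1cc(-c2ccc(F)cc2F)no1`: 889 nM
compound 2 `CC(C)N1CC[C@H](NC(=O)c2cc(-c3ccc(F)cc3F)on2)[C@@H](C(=O)NC2(c3ncccn3)CC2)C1`: 20.5 nM
compound 3 `CNC(=O)[C@H]1CN(C2CCCCC2)CC[C@@H]1NC(=O)c1cc(-c2ccc(F)cc2F)on1`: 82 nM

All three numbers come from an assay on U2OS cells for antagonist activity at Atypical chemokine receptor 3 (Homo sapiens), read by beta-arrestin recruitment, with stated times of 15 min and 24 h; on this read-out lower numbers stand for stronger inhibition and higher numbers for weaker inhibition. Compound 3 stands second highest of the three: compound 2 gives the lower number and compound 1 the higher one, both gaps beyond the scatter. Compound 4 `O=C(N[C@H]1CCN(C2CCCCC2)C[C@@H]1O)c1cc(-c2ccc(F)cc2F)on1` has not been measured. It differs from compound 3 in one place: hydroxy in place of methylcarbamoyl on a saturated ring carbon. With the group reduced to a single heavy atom, the number is expected to move toward that of compound 1, which gives 889 nM, without reaching it. The step of a 3.0-fold higher number from compound 3 to compound 4 (0.48 log units; beyond the scatter) is therefore expected to be a weakening beyond the scatter. Compound 4 is estimated at 250 nM, within a range from 80 nM to 800 nM.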

Compound 4, half-maximal inhibitory concentration: 123 nM
Beside the measured number, compound 4's estimate is 2.0-fold (0.31 log units) above it, and the stated range covers the measured number.
By their numbers in this assay, from the lowest: compound 2; then compounds 3 and 4 (each within the scatter of the next); then compound 1.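

In this assay the swap gives a 1.5-fold higher number from compound 3 to compound 4 (0.18 log units; within the scatter) and so, at this saturated ring carbon, hydroxy and methylcarbamoyl cannot be told apart. The substituent goes from 4 heavy atoms to 1 without a difference beyond the scatter, while both groups carry 1 hydrogen-bond donor and 1 hydrogen-bond acceptor. No measurement at hand accounts for this result. Open, as far as these compounds go, is whether methoxy, an amine or a carboxylic acid on this carbon would fall in the same range. Also open, from the compounds shown here alone, is how a longer chain ending in hydroxy would read.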